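The source may hold more compounds than are shown below. What is called first, only, known or untested is meant among the compounds shown, and "the series" means these compounds.

Measured so far in a functional assay on MCF7 cells (Homo sapiens) for antiproliferative activity, read by MTT assay, with a stated time of 72 h; a lower number here means a stronger inhibitor, a higher number a weaker inhibitor:
Compound 1 `O=[N+]([O-])c1ccc(-c2csc(N3N=C(c4ccc(N5CCCCC5)cc4)CC3c3ccc(Cl)cc3)n2)cc1` sits at the assay limit, > 100000 nM, a limit and not a number.
Compound 2 `Fc1ccc(-c2csc(N3N=C(c4ccc(N5CCCCC5)cc4)CC3c3ccc(Cl)cc3)n2)cc1` gives 23100 nM.
Compound 3 `Cc1ccc(-c2csc(N3N=C(c4ccc(N5CCCCC5)cc4)CC3c3ccc(Cl)cc3)n2)cc1` likewise sits at the limit, > 100000 nM, again a limit and not a number.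

Going by the values given here, compound 2 thus holds the only number in the set; the other two values rest at the limit of > 100000 nM in this assay, at which 2 of the 3 values shown sit. The step from nitro to fluoro, an at least 4.3-fold lower number from compound 1 to compound 2 (0.63 log units; beyond the scatter), and the step from fluoro to methyl, an at least 4.3-fold higher number from compound 2 to compound 3 (0.63 log units; beyond the scatter), both run beyond the scatter, while a step that the two limits leave unreadable from compound 1 to compound 3 cannot be read between two limits.

Compound 4 `Clc1ccc(C2CC(c3ccc(N4CCCCC4)cc3)=NN2c2nc(-c3ccc4ccccc4c3)cs2)cc1` is not yet measured. It differs from compound 2 by naphthalen-2-yl in place of 4-fluorophenyl on an aromatic carbon. Among the compounds with values here, no measured step swaps the whole aryl group on that carbon; the three measured steps only exchange a single substituent on a phenyl ring, and two of the three groups drive the value to the limit. Within the data shown here, compound 2 is the sole compound with a readable number, so any change away from fluoro has so far cost activity or left it unreadable. The expectation for compound 4 is therefore a weaker number, a 2.6-fold higher number from compound 2 to compound 4 (0.41 log units; beyond the scatter), with a real chance of another limit. Compound 4 is estimated at 60000 nM, between 15000 nM and 150000 nM.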

Compound 4, half-maximal inhibitory concentration: > 100000 nM
Compound 4 was reported as a limit (the forecaster's own chance of this, stated with the estimate: 45%); middle value at least 1.6-fold (0.22 log units) away from the limit.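

In this assay, going by these compounds alone, naphthalen-2-yl in place of 4-fluorophenyl gives an at least 4.3-fold higher number from compound 2 to compound 4 (0.63 log units; beyond the scatter), so exchanging the whole aryl group at this position, and not only a single substituent on a phenyl ring, also loses the one readable number. Compound 4 gives > 100000 nM, which is a limit and not a number. Compound 2 remains the only compound with a number, the steps among compound 1, compound 3 and compound 4 cannot be read, and the series now gathers at one end of the assay: the limit of > 100000 nM in this assay, at which 3 of the 4 values shown sit.

On these data alone, whether chloro or methoxy in place of fluoro, or a pyridinyl group in place of 4-fluorophenyl, would keep a readable number at this position stays open. So does whether any group here can bring the number below that of compound 2.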